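This account rests on a few compounds, and the source may have more. Where it says the series, first, only, none or still open, it means among the compounds named here.

Compound 2 `CNC(=O)c1cc(Oc2ccc3nc(NC(=O)Nc4ccc(Cl)cc4)sc3c2)ccn1` stands highest of the two numbers in a functional assay on SK-BR-3 cells (Homo sapiens) for inhibition, read by MTT assay, with a stated time of 2 days, tested at 10 uM (on this read-out higher numbers stand for more inhibition of growth at the one concentration tested and lower numbers for less inhibition of growth), where compound 2 gives 50.8%; compound 1 `CNC(=O)c1cc(Oc2ccc3nc(NC(=O)c4ccc(Cl)cc4Cl)sc3c2)ccn1` is the nearest point, and in this assay compound 1 gives 14%. Compound 3 `CNC(=O)c1cc(Oc2ccc3nc(NC(=O)c4cc(Cl)cc(Cl)c4)sc3c2)ccn1` differs from compound 2 by 3,5-dichlorophenyl in place of (4-chlorophenyl)amino on a carbonyl carbon. Among the measured compounds shown here, the only step that bears on it is a number 36.8 percentage points higher from compound 1 to compound 2 (beyond the scatter), which links a dichlorophenyl amide to the chlorophenyl urea; compound 3 returns to an amide, so a step of roughly that size in the opposite direction is expected, a number 30.8 percentage points lower from compound 2 to compound 3 (beyond the scatter). Compound 3 is therefore estimated at 20%, with a range from 5% to 45%.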

Compound 3, percent growth inhibition at one concentration: 9.62%
Compound 3: middle estimate off by 10.4 percentage points, on the high side; the measured number falls inside the stated range.
By their numbers in this assay, from the lowest: compounds 3 and 1 (each within the scatter of the next); then compound 2.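

In this assay, 3,5-dichlorophenyl on the carbonyl carbon gives a number 41.2 percentage points lower from compound 2 to compound 3 (beyond the scatter), so a second amide also stands far under the urea. Changing the chlorine pattern on the amide gives a number 4.4 percentage points lower from compound 1 to compound 3 (within the scatter), so these two chlorine patterns do not separate the amides. Nothing at hand explains the gap to the urea.

Going by these compounds, compound 2 differs from both amides in its amino link and also in its chlorine count, so the share of each stays open. A (3,5-dichlorophenyl)amino group or a 4-chlorophenyl group on the same carbonyl carbon would separate the two.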